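Chalcone-pyrazole series: methoxy removal on the carbonyl-side aryl

This account rests on a few compounds, and the source may have more. Where it says the series, first, only, none or still open, it means among the compounds named here.

Measured compounds in a functional assay on NCI-H522 cells (Homo sapiens) for cytotoxicity, read by sulforhodamine B assay, with a stated time of 48 h, tested at 10 uM; a lower number here means a stronger effect, a higher number a weaker effect of the compound at the concentration tested:
Compound 1, `COc1cc(-c2cc(/C=C/C(=O)c3ccc(Cl)c(Cl)c3)[nH]n2)cc(OC)c1OC`: -72%
Compound 2, `COc1ccc(C(=O)/C=C/c2cc(-c3cc(OC)c(OC)c(OC)c3)n[nH]2)cc1OC`: -95%

Compound 2 stands lowest of the two numbers in this assay; its nearest neighbour is compound 1, whose value lies higher by a margin beyond the scatter. Among the measured compounds shown here, the single measured step, a number 23 percentage points lower from compound 1 to compound 2 (beyond the scatter), exchanged the whole aryl on the carbonyl carbon and was modest in size. Compound 3, `COc1ccc(C(=O)/C=C/c2cc(-c3cc(OC)c(OC)c(OC)c3)n[nH]2)cc1`, differs from compound 2 by hydrogen in place of methoxy on an aromatic carbon. For the measured compounds named here, no measured step concerns the removal of one methoxy from this aryl, so the step from compound 1 to compound 2 bears on it only loosely, as a sign that the aryl on the carbonyl carbon moves the read-out by a modest amount. In this assay compound 3 is therefore expected to give -85%, within -100% to -55%, the expected step being a number 10 percentage points higher from compound 2 to compound 3 (within the scatter), likely within the scatter or a small weakening.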

Compound 3, a percentage reported as activity, at one concentration (the size of the read-out at that concentration, not a potency): -73%
Beside the measured number, compound 3's estimate is 12 percentage points below it; the measured number falls inside the stated range.
By their numbers in this assay, from the lowest: compound 2; then compounds 3 and 1 (each within the scatter of the next).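

In this assay, the single methoxy ortho to a methoxy group on the carbonyl-side aryl matters on its own: its replacement by hydrogen gives a number 22 percentage points higher from compound 2 to compound 3 (beyond the scatter). With a number 1 percentage points lower from compound 1 to compound 3 (within the scatter), 4-methoxyphenyl and 3,4-dichlorophenyl on the carbonyl carbon cannot be told apart in this read-out, while 3,4-dimethoxyphenyl in compound 2 stands apart from both by steps beyond the scatter. Among these three compounds, then, the difference seen for compound 2 goes with having both methoxy groups on this aryl, but nothing at hand explains why.

On these data alone, whether the position requires methoxy itself remains open, as a hydroxyl, an amine or a longer chain such as ethoxy at this carbon could separate a methoxy-specific result from a more general one. Also open, as far as these compounds go, is what plain phenyl, carrying neither methoxy, would give on the carbonyl carbon.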